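A few compounds are considered here, and "the series" means these few. Any claim that something is new, unique, unknown or untested is made for them only; others in the source may bear on it.

In an ADME assay on cells (Peritoneal macrophage cell, Mus musculus) for cytotoxicity, read by fluorescence and resazurin assay, with a stated time of 3 days (on this read-out lower numbers stand for higher toxicity in this test and higher numbers for lower toxicity in this test), compound 2 (`COc1ccccc1C(=O)Nc1[nH]nc(-c2ccccn2)c1C1CC1`) gives > 51000 nM, which is a limit of the assay and not a number. Its close relative, compound 1 (`O=C(Nc1[nH]nc(-c2ccccn2)c1C1CC1)c1ccccc1F`), gives > 64000 nM in this assay, and that too is only a limit. Neither compound therefore offers an exact reading to build on.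

The next compound, compound 3 (`O=C(Nc1[nH]nc(-c2ccccn2)c1C1CC1)c1c(Cl)cccc1Cl`), has 2,6-dichlorophenyl in place of 2-methoxyphenyl on a carbonyl carbon, with the rest of the molecule unchanged: 2,6-dichlorophenyl in place of 2-methoxyphenyl on a carbonyl carbon.

Going by the values given here, the one measured step that bears on this change is a step that the two limits leave unreadable from compound 1 to compound 2, where methoxy replaces fluoro on an aromatic carbon. It provides no size to carry over to the new change, and it gives no direction either. With so little to go on, no step beyond the usual scatter is expected in either direction. The expected step is an at least 1.0-fold lower number from compound 2 to compound 3 (0.00 log units; that floor lies within the scatter), and this is an estimate only. For compound 3 the estimated value is 50000 nM, with an expected range from 20000 nM to 85000 nM.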

Compound 3, half-maximal cytotoxic concentration: > 64000 nM
Compound 3 gave a limit, no number; the forecaster's own chance of this, stated with the estimate: 70%; middle value at least 1.2-fold (0.10 log units) away from the limit.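

The steps among compound 1, compound 2 and compound 3 cannot be read: in this assay all three give only limits of the assay, not numbers. The compounds shown leave open where the half-maximal cytotoxic concentration of each one lies, and whether 2-fluorophenyl, 2-methoxyphenyl or 2,6-dichlorophenyl on the carbonyl carbon changes it at all.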